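Replacing Cyano with Carboxy on Compound 2

The source may hold more compounds than are shown below. What is called first, only, known or untested is meant among the compounds shown, and "the series" means these compounds.

Going by the values given here, in a functional assay on KB cells (Homo sapiens) for antiproliferative activity (a higher number here means a weaker inhibitor, a lower number a stronger inhibitor), compound 2 `COc1ccc(S(=O)(=O)N2CCc3cccc(Nc4ccc(C#N)cc4)c32)cc1` gives 49.7 nM, the lowest number measured so far. The only other measured molecule, compound 1 `COc1ccc(Nc2cccc3c2N(S(=O)(=O)c2ccc(OC)cc2)CC3)cc1`, gives 1200 nM. Among the compounds with values here, the one measured step, a 24-fold lower number from compound 1 to compound 2 (1.38 log units; beyond the scatter), places cyano in place of methoxy on an aromatic carbon, and it is large.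

Compound 3 `COc1ccc(S(=O)(=O)N2CCc3cccc(Nc4ccc(C(=O)O)cc4)c32)cc1` changes that same carbon again, with carboxy in place of cyano on an aromatic carbon. Within the data shown here, no measured compound carries a carboxy group, so the data offer no direct guide. Still, the earlier step of a 24-fold lower number from compound 1 to compound 2 (1.38 log units; beyond the scatter) shows that a swap at this carbon can move the number a long way. Compound 2 also already holds the lowest number, so a rise is the expectation here. The estimated change is large: a 50-fold higher number from compound 2 to compound 3 (1.70 log units; beyond the scatter). For compound 3 the expected value is 2500 nM, within an estimated range of 300 nM to 20000 nM.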

Compound 3, half-maximal inhibitory concentration: 846 nM
Compound 3: middle estimate off by 3.0-fold (0.47 log units), on the high side; low and high end bracket the measured number.
By their numbers in this assay, from the lowest: compound 2; then compounds 3 and 1 (each within the scatter of the next).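

Changing this carbon can raise the number as well as lower it: in this assay, carboxy gives up most of what cyano gained, with a 17-fold higher number from compound 2 to compound 3 (1.23 log units; beyond the scatter) as the result. Carboxy and methoxy cannot be separated here, with a 1.4-fold lower number from compound 1 to compound 3 (0.15 log units; within the scatter) as their comparison on the same carbon, so among these three groups only cyano stands apart. Nothing measured on these compounds accounts for the difference between the groups.

On these data alone, it remains open whether a close relative of the nitrile or of the carboxy group, such as a primary amide or a methyl ester, would stay near compound 2 or fall in with compound 1 and compound 3. Nor do the compounds shown tell how a chlorine atom on this carbon would compare.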